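A few compounds are considered here, and "the series" means these few. Any claim that something is new, unique, unknown or untested is made for them only; others in the source may bear on it.

Two compounds have been measured so far in a functional assay on CHO cells for antagonist activity at prostaglandin E2 receptor EP3 subtype (Homo sapiens), read by cAMP accumulation; on this read-out higher numbers stand for weaker inhibition and lower numbers for stronger inhibition:

Compound 1 `CCC(CC)(c1nnc[nH]1)c1ccc(-c2ccc3cc(F)cc(F)c3c2)[nH]c1=O`: 350 nM
Compound 2 `CC(C)C(c1ccc(-c2ccc3cccc(F)c3c2)[nH]c1=O)N1CCCCS1(=O)=O`: 122 nM

Going by the values given here, compound 2 holds the lower of the two numbers, which on this read-out means the stronger inhibition; the gap to compound 1, the only other measured compound, is larger than the usual run-to-run scatter, so the difference between them can be taken as real. Compound 3 `CC(C)C(Cc1ncc[nH]1)c1ccc(-c2ccc3cccc(F)c3c2)[nH]c1=O` has not yet been measured in this assay. It differs from compound 2 in a single place: a group of 6 heavy atoms (4 carbon, 2 nitrogen; one five-membered aromatic ring with 2 hetero atoms) in place of a group of 8 heavy atoms (4 carbon, 1 nitrogen, 2 oxygen, 1 sulfur; one six-membered non-aromatic ring with 2 hetero atoms), on a saturated chain carbon bound to an aromatic carbon and a saturated chain carbon. Among the compounds with values here, no pair of measured compounds differs by this exchange alone, so there is no direct precedent for how large a shift it brings, and compound 1 differs from compound 2 in too many places to serve as a guide. Given that, a modest move toward a higher number is expected, a 2.5-fold higher number from compound 2 to compound 3 (0.39 log units; beyond the scatter), though a result within the scatter of compound 2 would not be surprising. Compound 3 is estimated at 300 nM, with a likely range from 80 nM to 1200 nM.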

Compound 3, half-maximal inhibitory concentration: 76 nM
Beside the measured number, compound 3's estimate is 3.9-fold (0.60 log units) above it; the measured number lies below the stated range.
By their numbers in this assay, from the lowest: compounds 3 and 2 (each within the scatter of the next); then compound 1.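

In this assay, putting (1H-imidazol-2-yl)methyl in place of the group holding a six-membered non-aromatic ring, on the saturated chain carbon bound to an aromatic carbon and a saturated chain carbon, gives a 1.6-fold lower number from compound 2 to compound 3 (0.21 log units; within the scatter). This position therefore holds two quite different groups with the read-out staying within the usual scatter: the entering group has a five-membered aromatic ring and a hydrogen-bond donor, whereas the leaving group has a non-aromatic ring, no such donor and a larger heavy-atom count. No measurement at hand speaks to the reason for this result.

As far as these compounds go, with only these two groups to compare at this position, it remains open which of their features, if any, matters for the read-out, and whether other groups would fare the same. A simple amine or a carboxylic acid on this carbon, or an imidazole ring attached directly without the methyl link, would show whether the position stays this accommodating or whether the read-out moves beyond the scatter.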